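The compounds below may be only part of what the source reports. "The series", "measured", "known", "first", "only" and "open" are said of these compounds alone.

Among the measured compounds shown here, in an ADME assay on microsomes from liver (Mus musculus) for metabolic stability, read by LC-MS, using NADPH, with stated times of 10 min and 30 min (a lower number here means slower removal, a higher number faster removal of the compound), compound 2 `CC(=O)N[C@@H]1CCCc2c1cncc2N1C(=O)c2ccc(Cl)cc2[C@H]1C` gives 43.5 mL/min/kg, the only full number so far. Compound 1 `CC[C@@H]1c2cc(Cl)ccc2C(=O)N1c1cncc2c1CCC[C@H]2NC(C)=O` gives < 20.2 mL/min/kg, which is a limit of the assay and not a number. Compound 3 `CC(=O)N[C@@H]1CCCc2c1cncc2N1Cc2cc(Cl)ccc2C1=O` has not yet been measured. It departs from compound 2 by hydrogen in place of methyl on a saturated ring carbon. For the measured compounds named here, one measured step bears on this change, though only by analogy: an at least 2.1-fold higher number from compound 1 to compound 2 (0.33 log units; beyond the scatter). That step also puts hydrogen in place of methyl, but on a saturated chain carbon bound to a saturated ring carbon, and it lies beyond the scatter. On this single precedent, a further modest rise in clearance is expected, not a fall. The expected change is a 1.6-fold higher number from compound 2 to compound 3 (0.21 log units; within the scatter). For compound 3, the estimate is 70 mL/min/kg, with an expected range of 38 mL/min/kg to 125 mL/min/kg.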

Compound 3, clearance: < 20.2 mL/min/kg
Compound 3 gave a limit, no number (the forecaster's own chance of this, stated with the estimate: 8%); middle value at least 3.4-fold (0.53 log units) away from the limit.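

On this saturated ring carbon, next to the ring nitrogen, hydrogen in place of methyl gives an at least 2.1-fold lower number from compound 2 to compound 3 (0.33 log units; beyond the scatter) in this assay, so slow removal here does not depend on having a group at this carbon. Read with an at least 2.1-fold higher number from compound 1 to compound 2 (0.33 log units; beyond the scatter), this sets methyl apart from both neighbours in the series: among ethyl in compound 1, methyl in compound 2 and hydrogen in compound 3, only methyl gives a full number. Compound 3 gives < 20.2 mL/min/kg, which is a limit of the assay and not a number, and the step between compound 1 and compound 3 cannot be read.

On these data alone, how much slower compound 1 and compound 3 are cleared than that limit shows stays open because both end there: the limit of < 20.2 mL/min/kg in this assay, at which 2 of the 3 values shown sit. Also open is how a hydroxymethyl, an amine or a fluorine at this carbon would behave.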